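From Trifluoromethyl to Dimethylamino: Expecting Compound 4

The compounds below may be only part of what the source reports. "The series", "measured", "known", "first", "only" and "open" are said of these compounds alone.

Three compounds share one core and differ only in the group on the six-membered aromatic ring of carbon only. Compound 1 `Cc1ccc(C(=O)NN2C(=O)NC3(CC3(C)C)C2=O)cc1` gives 100 mg/kg in a functional assay on the whole organism (Hindlimb) for inhibition, with Mus musculus as the target, with a stated time of 0.5 h (a higher number here means that more compound is needed for the effect, a lower number that less compound is needed), compound 2 `CC1(C)CC12NC(=O)N(NC(=O)c1ccc(Br)cc1)C2=O` gives 300 mg/kg, and compound 3 `CC1(C)CC12NC(=O)N(NC(=O)c1ccc(C(F)(F)F)cc1)C2=O` gives 30 mg/kg, the lowest of the three numbers. Compound 4 `CN(C)c1ccc(C(=O)NN2C(=O)NC3(CC3(C)C)C2=O)cc1` differs from compound 3 by a single change: dimethylamino in place of trifluoromethyl on an aromatic carbon. Going by the values given here, no measured step involves dimethylamino, so the only guide is the pair of steps into compound 3: a 3.3-fold lower number from compound 1 to compound 3 (0.52 log units; beyond the scatter) and a 10-fold lower number from compound 2 to compound 3 (1.00 log units; beyond the scatter). Both other groups tried gave higher numbers than trifluoromethyl, so for compound 4 a modest rise is expected, a 3.3-fold higher number from compound 3 to compound 4 (0.52 log units; beyond the scatter). Compound 4 is therefore estimated at 100 mg/kg, with a range from 30 mg/kg to 300 mg/kg.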

Compound 4, minimum effective dose: 300 mg/kg
For compound 4 the middle estimate is 3.0-fold (0.48 log units) below the measured one; the measured number falls inside the stated range.
By their numbers in this assay, from the lowest: compound 3; then compound 1; then compounds 2 and 4 (each within the scatter of the next).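

Dimethylamino at this place on the ring gives a 10-fold higher number from compound 3 to compound 4 (1.00 log units; beyond the scatter), and measured against bromo it gives no change at the digits printed from compound 2 to compound 4 (within the scatter), so two groups made of quite different atoms end up level at the high end of this small set. Methyl keeps its advantage over dimethylamino, with a 3.0-fold higher number from compound 1 to compound 4 (0.48 log units; beyond the scatter). Nothing available here explains why these groups rank this way.

On these data alone, it remains open whether a nitrile or a methoxy group at this same place would match the low number of trifluoromethyl or fall with bromo and dimethylamino.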